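Trimming a methoxy from a trimethoxyphenyl arm

The source may hold more compounds than are shown below. What is called first, only, known or untested is meant among the compounds shown, and "the series" means these compounds.

The study concerns three close analogues that share one core and differ only in the aryl group on the saturated chain carbon bound to an amide-type nitrogen. Compound 1 `CCOC(=O)C(C(=O)c1ccc(OC)cc1)C(NC(C)=O)c1ccc(C(C)C)cc1` gives 98.8% in an ADME assay on Vero cells (Chlorocebus sabaeus) for cytotoxicity, read by MTT assay, tested at 25 uM; on this read-out lower numbers stand for a stronger effect and higher numbers for a weaker effect at the one concentration tested. Compound 2 `CCOC(=O)C(C(=O)c1ccc(OC)cc1)C(NC(C)=O)c1cccc2ccccc12` carries naphthalen-1-yl in that position and gives 99.2%; the step of a number 0.4 percentage points higher from compound 1 to compound 2 (within the scatter) lies within the scatter. Compound 3 `CCOC(=O)C(C(=O)c1ccc(OC)cc1)C(NC(C)=O)c1cc(OC)c(OC)c(OC)c1` gives 97.8%, and its distance to compound 1 and to compound 2 also lies within the scatter, so the three numbers cannot be told apart.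

Compound 4 `CCOC(=O)C(C(=O)c1ccc(OC)cc1)C(NC(C)=O)c1ccc(OC)c(OC)c1` is the next analogue: hydrogen in place of methoxy on an aromatic carbon. For the measured compounds named here, the only measured step, a change of the whole aryl group, moved the read-out by a number 0.4 percentage points higher from compound 1 to compound 2 (within the scatter), i.e. not beyond the scatter; a smaller change, the loss of one methoxy, is therefore expected to move it even less. In this assay compound 4 is expected to give about 98%, between 90% and 100%, a step of a number 0.2 percentage points higher from compound 3 to compound 4 (within the scatter) that stays within the scatter.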

Compound 4, a percentage reported as activity, at one concentration (the size of the read-out at that concentration, not a potency): 99.1%
For compound 4 the middle estimate is 1.1 percentage points below the measured one, within the range that was stated.
By their numbers in this assay, from the lowest: compounds 3, 1, 4 and 2 (each within the scatter of the next).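

In this assay, removing one methoxy from the trimethoxyphenyl arm leaves a change that cannot be told from the scatter (a number 1.3 percentage points higher from compound 3 to compound 4 (within the scatter)), so this methoxy is not needed to keep the read-out where it stands. The 3,4-dimethoxyphenyl arm also cannot be told apart from naphthalen-1-yl (a number 0.1 percentage points lower from compound 2 to compound 4 (within the scatter)) or from 4-isopropylphenyl (a number 0.3 percentage points higher from compound 1 to compound 4 (within the scatter)), which means no read-out so far separates any of the four aryl groups at this position. Nothing on hand offers an explanation for this flat picture.

Going by these compounds, whether an amine or a carboxylic acid on this aryl ring would move the read-out remains open. So does the effect of replacing the acetyl group on the amide nitrogen with a longer chain.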